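The source may hold more compounds than are shown below. What is called first, only, known or untested is meant among the compounds shown, and "the series" means these compounds.

Of the compounds shown here, two have so far been measured in a functional assay on MDA-MB-231 cells (Homo sapiens) for inhibition, read by sulforhodamine B assay, tested at 10 uM; a higher number here means more inhibition at the concentration tested (going by the name of the read-out), a lower number less inhibition. Compound 1 `CN1CCN(c2ccc(C3=NN(S(=O)(=O)c4ccc(F)cc4)C(c4ccc(N(C)C)cc4)C3)cc2)CC1` gives 15.7% there, and compound 2 `CN(C)c1ccc(C2CC(c3ccc(-n4cncn4)cc3)=NN2C(=O)c2cc(Cl)cc(Cl)c2)cc1` gives 9.4%; the two numbers lie within the scatter of each other, so neither stands apart. Compound 3 `CN(C)c1ccc(C2CC(c3ccc(-n4cncn4)cc3)=NN2S(=O)(=O)c2ccc(F)cc2)cc1` has not yet been measured. It differs from compound 2 by (4-fluorophenyl)sulfonyl in place of (3,5-dichlorophenyl)carbonyl on an amine nitrogen in a ring. For the measured compounds named here, no measured pair isolates that change, so the expectation rests on the two values shown. The step of a number 3.6 percentage points higher from compound 2 to compound 3 (within the scatter) is expected to stay within the scatter, since compound 1, which carries the same entering group, gives 15.7%. Compound 3 is estimated at 13%, with a range from 3% to 25%.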

Compound 3, a percentage reported as inhibition, at one concentration (the size of the read-out at that concentration, not a potency): 12.1%
Estimate against measurement, compound 3: 0.9 percentage points above; low and high end bracket the measured number.
By their numbers in this assay, from the lowest: compounds 2, 3 and 1 (each within the scatter of the next).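

In this assay the change on the amine nitrogen in the ring now has its own pair: (4-fluorophenyl)sulfonyl in place of (3,5-dichlorophenyl)carbonyl gives a number 2.7 percentage points higher from compound 2 to compound 3 (within the scatter) at this position. The aromatic carbon also has a pair, where 1H-1,2,4-triazol-1-yl in place of 4-methylpiperazin-1-yl gives a number 3.6 percentage points lower from compound 1 to compound 3 (within the scatter) in the same assay. Nothing available explains either step. Neither place has yet shown a step beyond the scatter. From the compounds shown here alone, whether an acetyl group on that ring nitrogen or a morpholine on that aromatic carbon would do so remains open.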